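From a secondary to a tertiary amide on a saturated ring

This account rests on a few compounds, and the source may have more. Where it says the series, first, only, none or still open, it means among the compounds named here.

Of the compounds shown here, two built on the same core have been measured in an assay on isolated protein for inhibition of protein kinase C theta type (Homo sapiens), read by TR-FRET, with a stated time of 2 h; on this read-out higher numbers stand for weaker inhibition and lower numbers for stronger inhibition. Compound 1 `CO[C@H]1CC[C@@H](Nc2cc(NCc3cnccc3C(F)(F)F)ncc2C#N)CC1` gives 58 nM, and compound 2 `CNC(=O)[C@H]1CC[C@@H](Nc2cc(NCc3cnccc3C(F)(F)F)ncc2C#N)CC1` gives 27 nM. Among the compounds with values here, the step between them, a 2.1-fold lower number from compound 1 to compound 2 (0.33 log units; beyond the scatter), is the only measured step so far, and it leaves compound 2 with the lowest number of the two, its nearest neighbour being compound 1 with a higher number beyond the scatter.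

Compound 3 `CN(C)C(=O)[C@H]1CC[C@@H](Nc2cc(NCc3cnccc3C(F)(F)F)ncc2C#N)CC1` is the next variation. Its difference from compound 2 is methyl in place of hydrogen on an amide-type nitrogen. Within the data shown here, no measured step covers this kind of change: the one available step, from methoxy to methylcarbamoyl, exchanges the whole group and says nothing about adding a methyl to the amide nitrogen while the carbonyl stays. The expectation therefore rests on compound 2 alone, and the estimated step of a 1.5-fold higher number from compound 2 to compound 3 (0.17 log units; within the scatter) is set at roughly no change beyond the scatter, with a wide range to either side to allow for either direction. Compound 3 is expected to give 40 nM in this assay, within a range from 12 nM to 130 nM.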

Compound 3, half-maximal inhibitory concentration: 38 nM
Estimate against measurement, compound 3: 1.1-fold (0.02 log units) above, within the range that was stated.
By their numbers in this assay, from the lowest: compounds 2, 3 and 1 (each within the scatter of the next, the first and the last beyond it).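

Replacing the amide hydrogen with methyl gives a 1.4-fold higher number from compound 2 to compound 3 (0.15 log units; within the scatter) in this assay, so on this saturated ring carbon the amide can carry a second methyl on its nitrogen without a change that rises above the scatter. Within the data shown here, the comparison with the methoxy group also becomes less clear-cut: the exchange for dimethylcarbamoyl gives a 1.5-fold lower number from compound 1 to compound 3 (0.18 log units; within the scatter), and of the two exchanges only the one for methylcarbamoyl, a 2.1-fold lower number from compound 1 to compound 2 (0.33 log units; beyond the scatter), lies beyond the scatter. Nothing measured here explains these numbers or shows what the amide hydrogen or the added methyl does.

The three compounds do not show how far the amide nitrogen can be built out, and a longer chain such as ethyl, or a pyrrolidine ring closed through that nitrogen, would test this directly. They also leave open how much depends on the amide itself, which a primary carboxamide or a carboxylic acid on the same saturated ring carbon would help to show.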